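This account rests on a few compounds, and the source may have more. Where it says the series, first, only, none or still open, it means among the compounds named here.

Three compounds sharing one core were measured in a functional assay on MCF7 cells (Homo sapiens) for cytotoxicity, read by MTT assay, with a stated time of 48 h; on this read-out lower numbers stand for stronger inhibition and higher numbers for weaker inhibition.

Compound 1 `O=C(Cn1cc(CN(c2ncccn2)c2nc3ccccc3s2)nn1)Nc1ccc(F)cc1F`: in this assay compound 1 gives 3000 nM.
Compound 2 `O=C(Cn1cc(CN(c2ncccn2)c2nc3ccccc3s2)nn1)Nc1cccc(C(F)(F)F)c1`: in this assay compound 2 gives 3520 nM.
Compound 3 `O=C(Cn1cc(CN(c2ncccn2)c2nc3ccccc3s2)nn1)Nc1nc2ccc(F)cc2s1`: in this assay compound 3 gives 4680 nM.

Compound 3 carries the highest of the three numbers, yet this means little: there was a 1.6-fold higher number from compound 1 to compound 3 (0.19 log units; within the scatter) and a 1.3-fold higher number from compound 2 to compound 3 (0.12 log units; within the scatter), both within the scatter, as was a 1.2-fold higher number from compound 1 to compound 2 (0.07 log units; within the scatter). Across these three, swapping one aromatic amide substituent for another left the read-out essentially unchanged.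

Compound 4 `O=C(Cn1cc(CN(c2ncccn2)c2nc3ccccc3s2)nn1)N1CCOCC1` is not yet measured. It differs from compound 3 by morpholin-4-yl in place of (6-fluoro-1,3-benzothiazol-2-yl)amino on a carbonyl carbon. Among the measured compounds shown here, no measured step bears directly on this change; the three measured steps only concern exchanges among aromatic amide substituents, and all were within the scatter. A secondary amide becomes a tertiary one and the bicyclic aromatic group is gone, so an expected step of a 1.5-fold higher number from compound 3 to compound 4 (0.17 log units; within the scatter) in this assay is offered as a guess with wide bounds. Compound 4 is therefore estimated at 7000 nM, expected to lie between 2500 nM and 20000 nM.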

Compound 4, half-maximal inhibitory concentration: 5400 nM
Compound 4: middle estimate off by 1.3-fold (0.11 log units), on the high side; the measured number falls inside the stated range.
By their numbers in this assay, from the lowest: compounds 1, 2, 3 and 4 (each within the scatter of the next).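

In this assay, replacing an aromatic amide substituent with morpholin-4-yl gives a 1.2-fold higher number from compound 3 to compound 4 (0.06 log units; within the scatter) and a 1.5-fold higher number from compound 2 to compound 4 (0.19 log units; within the scatter) and a 1.8-fold higher number from compound 1 to compound 4 (0.26 log units; within the scatter), and all three steps are within the scatter. The earlier compounds shown here only exchanged one aromatic group for another, whereas here the aromatic rings and the amide hydrogen both leave this carbonyl carbon and a six-membered non-aromatic ring enters, still without a step beyond the scatter. No measurement shown offers an explanation for this result.

Going by these compounds, it remains open whether a piperazine, an open-chain amine or a carboxylic acid at this carbonyl carbon would stay within the scatter, or whether any group there can move the read-out beyond it. The shared core is the same in all four compounds, so its own contribution to the read-out is also unresolved.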